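A Chloro Substituent and Microsomal Clearance Across Two Cores

The source may hold more compounds than are shown below. What is called first, only, known or untested is meant among the compounds shown, and "the series" means these compounds.

Compound 1, `Cc1nnc(C2CCN(c3ccccn3)CC2)n1-c1ccccc1`: in an in vitro ADME assay on microsomes from liver (Homo sapiens) for metabolic stability (on this read-out higher numbers stand for fast clearance and lower numbers for slow clearance), compound 1 gives < 8 mL.min-1.g-1, which is a limit of the assay rather than a number.
Compound 2, `Cc1nnc(C2CCN(c3ccccn3)CC2)n1-c1ccc(Cl)cc1`: in this assay compound 2 gives 23 mL.min-1.g-1.
Compound 3, `c1ccc(Cn2c(Cn3nccn3)nnc2C2CCN(c3ccccn3)CC2)cc1`: in this assay compound 3 gives 19 mL.min-1.g-1.

Within the data shown here, the one measured step is the change (chloro in place of hydrogen on an aromatic carbon), which produced an at least 2.8-fold higher number from compound 1 to compound 2 (0.45 log units; beyond the scatter). The size of that step can only be given as a lower bound because of the limit of < 8 mL.min-1.g-1 in this assay, at which 1 of the 3 values shown sits. Compound 3 and compound 2 sit within the scatter of each other in this assay. The difference between the core of compound 1 and the core of compound 3 is not broken down here.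

Compound 4, `Clc1cccc(Cn2c(Cn3nccn3)nnc2C2CCN(c3ccccn3)CC2)c1`, is not yet measured. It differs from compound 3 by chloro in place of hydrogen on an aromatic carbon. Among the measured compounds shown here, this is the same kind of change as the one from compound 1 to compound 2, but not the same: there the chloro sits para to a large group, here it sits meta to a large group, and the two cores differ as well.

Resting on the step from compound 1 to compound 2 in this assay, which is at least modest, compound 4 is expected to show a higher number than compound 3, with an estimated step of a 1.8-fold higher number from compound 3 to compound 4 (0.27 log units; within the scatter). Because an at least 2.8-fold higher number from compound 1 to compound 2 (0.45 log units; beyond the scatter) is only a bound, its true size is uncertain, so the expectation for compound 4 is placed at 35 mL.min-1.g-1, with an estimated range from 17 mL.min-1.g-1 to 75 mL.min-1.g-1.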

Compound 4, intrinsic clearance in microsomes: 104 mL.min-1.g-1
The estimate for compound 4 lay 3.0-fold (0.47 log units) below the measured number; measured number outside the range, above it.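

Going from benzyl to 3-chlorobenzyl gave, in this assay, a 5.5-fold higher number from compound 3 to compound 4 (0.74 log units; beyond the scatter), so the higher number seen with chloro on the core of compound 1 also appears on the core of compound 3. The direction of the change therefore carries across the two cores shown, but its size cannot be compared between them: the same change on two cores in this assay, an at least 2.8-fold higher number (0.45 log units; beyond the scatter) from compound 1 to compound 2 and a 5.5-fold higher number (0.74 log units; beyond the scatter) from compound 3 to compound 4; the limit leaves it open whether they differ The two pairs also differ in where the chloro sits as well as in their cores, so they cannot show whether either difference affects the size of the step, or predict the step on any further core.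

The compounds shown leave open whether the higher number is particular to chloro or would also follow from fluoro, methyl or methoxy in the same place, and whether an amine or a carboxylic acid there would move the number the other way. They also leave open what 3-chlorophenyl would give on the core of compound 1, a comparison that would set the two cores side by side with the chloro in one place.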